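This account rests on a few compounds, and the source may have more. Where it says the series, first, only, none or still open, it means among the compounds named here.

Compound 2 `O=C(CSC(=S)N[C@H]1CCOC1=O)Nc1ccc(F)cc1` and compound 1 `O=C(CSC(=S)N[C@H]1CCOC1=O)Nc1ccc(Br)cc1` share one core and differ only in the halogen on the aromatic ring. In a functional assay on EC9706 cells (Homo sapiens) for cytotoxicity, read by MTT assay, with a stated time of 72 h (a lower number here means a stronger inhibitor, a higher number a weaker inhibitor), compound 1 gives 67400 nM, and in this assay compound 2 gives 67100 nM; the two numbers sit within the scatter of each other, so neither can be ranked against the other. Within the data shown here, the only measured step, a 1.0-fold lower number from compound 1 to compound 2 (0.00 log units; within the scatter), shows that exchanging one halogen for another left the number essentially unchanged. Compound 3 `CCOC(=O)c1ccc(NC(=O)CSC(=S)N[C@H]2CCOC2=O)cc1` is not yet measured; it differs from compound 2 by ethoxycarbonyl in place of fluoro on an aromatic carbon. Among the measured compounds shown here, no measured step involves this group, so the halogen exchange offers only a weak guide. Because the change from compound 1 to compound 2 was a 1.0-fold lower number from compound 1 to compound 2 (0.00 log units; within the scatter), compound 3 is expected to stay close to compound 2, with a step of about a 1.1-fold lower number from compound 2 to compound 3 (0.05 log units; within the scatter). Compound 3 is therefore estimated at 60000 nM, within 20000 nM to 180000 nM.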

Compound 3, half-maximal inhibitory concentration: 112000 nM
Estimate against measurement, compound 3: 1.9-fold (0.27 log units) below, within the range that was stated.
By their numbers in this assay, from the lowest: compounds 2, 1 and 3 (each within the scatter of the next).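

In this assay the exchange of a single halogen atom for the much larger ethoxycarbonyl, with 5 heavy atoms and 2 hydrogen-bond acceptors, gives a 1.7-fold higher number from compound 2 to compound 3 (0.22 log units; within the scatter) and, against the bromo compound, a 1.7-fold higher number from compound 1 to compound 3 (0.22 log units; within the scatter) and both steps stay within the scatter. The earlier pair showed only one halogen exchanged for another, whereas these steps show that a group of a different kind, on this aromatic carbon para to a large group, also leaves the number unresolved from those of the halogen compounds. Nothing measured here bears on this result.

From the compounds shown here alone, how an amine, a carboxylic acid or a longer alkyl chain would read at this position remains open. So does whether any change here can produce a step beyond the scatter.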